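Sulfo Group at Another Oxygen: What to Expect

A few compounds are considered here, and "the series" means these few. Any claim that something is new, unique, unknown or untested is made for them only; others in the source may bear on it.

Compound 1, `CCCCCCCCCCCCCCCCO[C@H]1O[C@H](CO)[C@@H](O)[C@H](O)[C@H]1NC(C)=O`, gives 29.3 uM in a functional assay on A-375 cells (Homo sapiens), read by thymidine incorporation; on this read-out higher numbers stand for weaker inhibition and lower numbers for stronger inhibition.
Compound 2, `CCCCCCCC/C=C\CCCCCCCCO[C@H]1O[C@H](CO)[C@@H](O)[C@H](O)[C@H]1NC(C)=O`, gives 4.8 uM in this assay.
Compound 3, `CCCCCCCC/C=C\CCCCCCCCO[C@H]1O[C@H](CO)[C@@H](O)[C@H](OS(=O)(=O)O)[C@H]1NC(C)=O`, gives 2.1 uM in this assay.

Among these three, compound 2 holds the second highest number in this assay, meaning its inhibition is weaker than that of compound 3 and stronger than that of compound 1. Its nearest neighbour is compound 3, reached by a 2.3-fold lower number from compound 2 to compound 3 (0.36 log units; beyond the scatter); its furthest is compound 1, from which it is reached by a 6.1-fold lower number from compound 1 to compound 2 (0.79 log units; beyond the scatter).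

Compound 4, `CCCCCCCC/C=C\CCCCCCCCO[C@H]1O[C@H](COS(=O)(=O)O)[C@@H](O)[C@H](O)[C@H]1NC(C)=O`, has not yet been measured. It differs from compound 2 in one place: sulfo in place of hydrogen on an oxygen on a saturated carbon. Going by the values given here, only one measured step resembles this change. In going from compound 2 to compound 3 a sulfo group also replaced a hydrogen on an oxygen on a saturated carbon, though at a different oxygen of the shared core, and that step gave a 2.3-fold lower number from compound 2 to compound 3 (0.36 log units; beyond the scatter). Among the compounds with values here, no measured pair shows the effect of a sulfo group at the oxygen that is changed here, so the expectation rests on that single neighbouring step alone.

A modest move toward a lower number is therefore expected, a 1.7-fold lower number from compound 2 to compound 4 (0.23 log units; within the scatter), though a change within the scatter would not be surprising. Compound 4 is estimated at 2.8 uM, in a range from 1 uM to 7.5 uM.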

Compound 4, concentration for 50% inhibition: 0.6 uM
Compound 4: the middle estimate sits 4.7-fold (0.67 log units) above what was measured; the measured number lies below the stated range.
By their numbers in this assay, from the lowest: compound 4; then compound 3; then compound 2; then compound 1.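

In this assay, going by these compounds alone, turning hydroxymethyl into (sulfooxy)methyl gives an 8.0-fold lower number from compound 2 to compound 4 (0.90 log units; beyond the scatter) and provides the first direct reading of a sulfo group at this oxygen of the shared core. The same kind of change at a different oxygen gave a 2.3-fold lower number from compound 2 to compound 3 (0.36 log units; beyond the scatter), so the two sulfo compounds do not behave alike: compound 3 gives 2.1 uM while compound 4 gives 0.6 uM, which shows that the outcome of this change depends on which oxygen carries the group. The numbers record this difference between the two oxygens, but no supporting information is available to explain it.

Still open, as far as these compounds go, is whether the sulfo group is specifically required at this oxygen, or whether a phosphate or a carboxylic acid attached at the same place would give a similar number. It is also unknown whether the sulfo group would lower the number to a similar extent on the saturated chain of compound 1, and whether placing sulfo groups on both oxygens together would take the number lower still.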